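The source may hold more compounds than are shown below. What is called first, only, known or untested is meant among the compounds shown, and "the series" means these compounds.

Three compounds have been measured in a functional assay on A549 cells (Homo sapiens) for antiproliferative activity, read by sulforhodamine B assay, with a stated time of 48 h; on this read-out higher numbers stand for weaker inhibition and lower numbers for stronger inhibition:

- compound 1, `COc1ccc(C[C@@H](O)/C=C/C=C/C(=O)N2CCCCC2)cc1OC`, gives 16400 nM
- compound 2, `COc1ccc(C[C@@H](O)/C=C/C=C/C(=O)NCc2ccc(Cl)cc2)cc1OC`, gives 16500 nM
- compound 3, `COc1ccc(C[C@@H](O)/C=C/C=C/C(=O)N2CCN(C)CC2)cc1OC`, gives 22200 nM

All three share the same core and differ only in the group on the carbonyl carbon. The steps among them are small: a 1.0-fold higher number from compound 1 to compound 2 (0.00 log units; within the scatter), a 1.4-fold higher number from compound 1 to compound 3 (0.13 log units; within the scatter) and a 1.3-fold higher number from compound 2 to compound 3 (0.13 log units; within the scatter). Compound 3 therefore stands apart from the other two by steps that are all within the scatter, so the three numbers cannot be told apart with confidence.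

Compound 4, `COc1ccc(C[C@@H](O)/C=C/C=C/C(=O)N2CCN(c3ccccc3)CC2)cc1OC`, keeps the core of compound 3 and changes the substituent on the piperazine: phenyl in place of methyl on an amine nitrogen in a ring. Going by the values given here, none of the measured steps touches this position; they only swap the whole group on the carbonyl carbon, and each of those swaps left the number essentially unchanged. Among the compounds with values here, there is thus no measured step that points to a shift in either direction, and the working expectation is a change no larger than the scatter, a 1.4-fold lower number from compound 3 to compound 4 (0.14 log units; within the scatter).

Compound 4 is accordingly estimated to give 16000 nM in this assay, with a range from 5000 nM to 50000 nM.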

Compound 4, half-maximal inhibitory concentration: 14200 nM
The estimate for compound 4 lay 1.1-fold (0.05 log units) above the measured number, within the range that was stated.
By their numbers in this assay, from the lowest: compounds 4, 1, 2 and 3 (each within the scatter of the next).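

In this assay, going by these compounds alone, the earlier steps swapped the whole group on the carbonyl carbon, whereas this one changes only the substituent on an amine nitrogen in a ring, and phenyl in place of methyl gives a 1.6-fold lower number from compound 3 to compound 4 (0.19 log units; within the scatter) in the same read-out. The position therefore takes a substituent of six heavy atoms with an aromatic ring where a single carbon stood, and the step stays within the scatter despite that jump in size. This one step shows only that going from methyl to phenyl here does not move the number measurably, and nothing available explains that result.

The compounds shown leave open whether a different group on this nitrogen, such as a benzyl, an acetyl or a phenyl ring bearing a chlorine or a methoxy group, would move the number beyond the scatter. They also leave open whether changes elsewhere, such as replacing the hydroxyl on the chain of the shared core with a ketone or a methoxy group, would matter more than changes at this nitrogen.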